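Replacing 4-methoxyphenyl with 2,6-dichlorophenyl

A few compounds are considered here, and "the series" means these few. Any claim that something is new, unique, unknown or untested is made for them only; others in the source may bear on it.

Compound 1 `C[C@H]1CC[C@@H]2[C@@H](OC(=O)[C@]23CC(c2ccc(Br)cc2)N(c2ccccc2)O3)[C@]2(C)C(=O)C=C[C@@]12O`, compound 2 `C[C@H]1CC[C@@H]2[C@@H](OC(=O)[C@]23CC(c2ccc(Cl)cc2)N(c2ccccc2)O3)[C@]2(C)C(=O)C=C[C@@]12O` and compound 3 `COc1ccc(C2C[C@@]3(ON2c2ccccc2)C(=O)O[C@@H]2[C@H]3CC[C@H](C)[C@]3(O)C=CC(=O)[C@@]23C)cc1` share one core and differ in a single group on an aromatic carbon. In a physicochemical assay for lipophilicity (a higher number here means a more lipophilic compound, a lower number a more polar compound), compound 1 gives 4, compound 2 gives 3.87, and compound 3 gives 3.25, the lowest of the three numbers. The next compound is compound 4 `C[C@H]1CC[C@@H]2[C@@H](OC(=O)[C@]23CC(c2c(Cl)cccc2Cl)N(c2ccccc2)O3)[C@]2(C)C(=O)C=C[C@@]12O`, in which 2,6-dichlorophenyl takes the place of 4-methoxyphenyl on a saturated ring carbon: 2,6-dichlorophenyl in place of 4-methoxyphenyl on a saturated ring carbon. For the measured compounds named here, no measured step makes this exact change, but three bear on it. The closest is a number 0.62 log units lower from compound 2 to compound 3 (beyond the scatter), with methoxy in place of chloro, and its bromo counterpart is a number 0.75 log units lower from compound 1 to compound 3 (beyond the scatter). Swapping the two halogens gives a number 0.13 log units lower from compound 1 to compound 2 (within the scatter). Read backwards, the two methoxy steps point upward in this assay. Going by the values given here, no measured compound carries the 2,6-dichlorophenyl group, so the size remains uncertain. The expected change, beyond the scatter, is a number 0.95 log units higher from compound 3 to compound 4 (beyond the scatter). For compound 4 the estimated value is 4.2, with an expected range from 3.7 to 4.7.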

Compound 4, partition coefficient: 4.45
For compound 4 the middle estimate is 0.25 log units below the measured one; the measured number falls inside the stated range.
By their numbers in this assay, from the lowest: compound 3; then compounds 2 and 1 (each within the scatter of the next); then compound 4.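

In this assay, 2,6-dichlorophenyl on this saturated ring carbon gives the highest number of the series, with a number 1.20 log units higher from compound 3 to compound 4 (beyond the scatter), a number 0.58 log units higher from compound 2 to compound 4 (beyond the scatter) and a number 0.45 log units higher from compound 1 to compound 4 (beyond the scatter). For the compounds shown here, the earlier compounds showed only that the group on the aromatic carbon could lower the number, whereas this result shows that the aryl group at this position can also lift it clearly above both the 4-bromophenyl and 4-chlorophenyl compounds. Nothing shown here gives a reason for these rises.

The change from 4-chlorophenyl to 2,6-dichlorophenyl alters both how many chloro groups the ring carries and where they sit, and the compounds shown do not separate those two changes. Also open, from the compounds shown here alone, is where a phenyl group carrying an amine or a carboxylic acid would fall at this carbon.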